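A few compounds are considered here, and "the series" means these few. Any claim that something is new, unique, unknown or untested is made for them only; others in the source may bear on it.

Of the compounds shown here, two have so far been measured in a functional assay on ECa-109 cells (Homo sapiens) for cytotoxicity, read by MTT assay, with a stated time of 72 h; a lower number here means a stronger inhibitor, a higher number a weaker inhibitor. Compound 1, `CCOc1ccc(COc2c(OC)cc(/C=C/C(=O)N3CCN(Cc4ccc(Cl)c(Cl)c4)CC3)cc2OC)cc1`, gives 1100 nM. Compound 2, `O=C(COC(=O)/C=C/c1ccc(O)c(O)c1)Nc1ccc(Cl)cc1`, gives 175000 nM. Of the two numbers, compound 2 holds the higher one, and its gap to compound 1 lies beyond the scatter of repeated measurements, so compound 2 is the weaker inhibitor of the pair.

Compound 3, `COc1ccc(NC(=O)COC(=O)/C=C/c2ccc(O)c(O)c2)cc1`, has not yet been measured. It differs from compound 2 in one place: methoxy in place of chloro on an aromatic carbon. Among the measured compounds shown here, no pair of measured compounds differs in this way alone, so nothing measured shows what this change does to the read-out. Compound 1 rests on a different core and gives no guide either. For the measured compounds named here, with no measured step to lean on, the change is expected to leave the number roughly where compound 2 stands, or to move it only modestly in either direction. Compound 3 is therefore expected to give about 200000 nM in this assay, within a range from 60000 nM to 600000 nM. That estimate corresponds to an expected step of a 1.1-fold higher number from compound 2 to compound 3 (0.06 log units; within the scatter).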

Compound 3, half-maximal inhibitory concentration: 190000 nM
Compound 3: the middle estimate sits 1.1-fold (0.02 log units) above what was measured; low and high end bracket the measured number.
By their numbers in this assay, from the lowest: compound 1; then compounds 2 and 3 (each within the scatter of the next).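

In this assay, among the compounds shown here, the change from 4-chlorophenyl to 4-methoxyphenyl gives a 1.1-fold higher number from compound 2 to compound 3 (0.04 log units; within the scatter) and so provides the first measured step at this position on the aromatic ring. Compound 2 and compound 3 cannot be told apart here, even though methoxy brings one more heavy atom than chloro and a hydrogen-bond acceptor that chloro does not count. This single pair shows that this one exchange, para to a large group, leaves the read-out within the usual scatter, but nothing available explains that outcome.

Chloro and methoxy are the only two groups shown at this position, so it remains open whether an amine, a carboxylic acid or a longer chain such as butoxy would also leave the number within the scatter of compound 2 or shift it beyond. On these data alone, it also remains open whether the same exchange would behave in the same way on a different core, such as the core of compound 1.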